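This account rests on a few compounds, and the source may have more. Where it says the series, first, only, none or still open, it means among the compounds named here.

Measured in an ADME assay on HEp-2 cells (Homo sapiens) for cytotoxicity, read by MTT assay, with a stated time of 3 days; on this read-out higher numbers stand for lower toxicity in this test and lower numbers for higher toxicity in this test: compound 1 `CCC[C@H](CCn1cncn1)c1ccc(F)cc1` gives 39.3 ug/mL; compound 2 `CCC[C@@H](CCn1cncn1)c1ccc(F)cc1` gives 55.3 ug/mL; compound 3 `CCC[C@@H](CCn1cncn1)c1ccc(Cl)cc1` gives 36.6 ug/mL.

Compound 2 holds the highest of the three numbers in this assay, yet both of its steps to the other two stay within the scatter: a 1.4-fold higher number from compound 1 to compound 2 (0.15 log units; within the scatter) and a 1.5-fold lower number from compound 2 to compound 3 (0.18 log units; within the scatter). The first of these rests on (the fact that compounds 1 and 2 differ only in the configuration as drawn). Compound 4 `CCCC[C@@H](CCn1cncn1)c1ccc(F)cc1` is reached from compound 2 by methyl in place of hydrogen on a saturated chain carbon, four bonds along the chain from an aromatic carbon. Going by the values given here, neither measured step touches the chain, so there is no direct precedent for this change; both measured steps were within the scatter, and no step beyond the scatter is expected here either. Compound 4 is therefore expected to give 45 ug/mL in this assay, within 22 ug/mL to 90 ug/mL, which means an estimated step of a 1.2-fold lower number from compound 2 to compound 4 (0.09 log units; within the scatter).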

Compound 4, half-maximal cytotoxic concentration: 36 ug/mL
For compound 4 the middle estimate is 1.3-fold (0.10 log units) above the measured one; measured number inside the range.
By their numbers in this assay, from the lowest: compounds 4, 3, 1 and 2 (each within the scatter of the next).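

In this assay, going by these compounds alone, methyl in place of hydrogen on a saturated chain carbon, four bonds along the chain from an aromatic carbon, gives a 1.5-fold lower number from compound 2 to compound 4 (0.19 log units; within the scatter), a change in chain length that the earlier steps did not cover. Going from propyl to butyl at this position therefore leaves the number within the scatter, as the configuration and halogen changes did. Nothing given here bears on a cause for this step.

Open, going by these compounds, is how a longer chain such as hexyl would read, and how an amine or a carboxylic acid in place of that methyl would read.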